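The source may hold more compounds than are shown below. What is called first, only, known or untested is meant among the compounds shown, and "the series" means these compounds.

Measured compounds:
Compound 1, `Cc1ccc(-c2c(C)c(-c3ccc4c(c3)CCO4)c(C(OC(C)(C)C)C(=O)O)c(C)c2NS(C)(=O)=O)cc1C`: 38000 nM
Compound 2, `Cc1ccc(-c2c(C)c(-c3ccc4c(c3C)CCCO4)c(C(OC(C)(C)C)C(=O)O)c(C)c2NS(C)(=O)=O)cc1C`: 24000 nM
Compound 3, `Cc1ccc(-c2c(C)c(-c3ccc(C)c(C)c3)c(C(OC(C)(C)C)C(=O)O)c(C)c2NC(=O)c2ccccc2)cc1C`: 9100 nM

Compound 3 stands at the low end of these three numbers in an ADME assay on MT4 cells (Homo sapiens) for cytotoxicity, read by MTT assay, with a stated time of 4 days (on this read-out higher numbers stand for lower toxicity in this test and lower numbers for higher toxicity in this test), beyond the scatter from both compound 2 and compound 1, so of the measured set it shows the highest toxicity in this test. Compound 4, `CCNC(=O)Nc1c(C)c(C(OC(C)(C)C)C(=O)O)c(-c2ccc(C)c(C)c2)c(C)c1-c1ccc(C)c(C)c1`, differs from compound 3 in one place: ethylamino in place of phenyl on a carbonyl carbon, so that the benzamido group becomes an (ethylcarbamoyl)amino group.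

For the measured compounds named here, only one measured step is available, a 1.6-fold lower number from compound 1 to compound 2 (0.20 log units; within the scatter), and it concerns the fused bicyclic group on an aromatic carbon, not the amide. Going by the values given here, no measured step touches the carbonyl carbon, so the change from compound 3 to compound 4 has no direct precedent here. Given that the three measured numbers all lie within a narrow band, a small move, likely within the scatter and if anything toward a higher number, is expected for compound 4, that is a 1.5-fold higher number from compound 3 to compound 4 (0.19 log units; within the scatter). Compound 4 is therefore estimated at 14000 nM, with a range from 6000 nM to 40000 nM.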

Compound 4, half-maximal cytotoxic concentration: 15000 nM
The estimate for compound 4 lay 1.1-fold (0.03 log units) below the measured number, within the range that was stated.
By their numbers in this assay, from the lowest: compounds 3, 4, 2 and 1 (each within the scatter of the next, the first and the last beyond it).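

For the compounds shown here, the earlier compounds included no step at this carbonyl carbon, so this pair gives the first direct reading of a change there. In this assay, ethylamino in place of phenyl, which turns benzamido into (ethylcarbamoyl)amino, gives a 1.6-fold higher number from compound 3 to compound 4 (0.22 log units; within the scatter), so removing the phenyl ring from this position does not move the number beyond the usual scatter of repeated measurements. No measurement shown here offers an explanation for this result.

Still open, from the compounds shown here alone, is whether a longer chain such as n-butylamino, or a ring amine such as morpholine, would keep the number within the scatter on the same carbonyl carbon. Also open, going by these compounds, is how a methoxy group in that place, which would give a carbamate, would compare with ethylamino and phenyl.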